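The source may hold more compounds than are shown below. What is called first, only, known or untested is meant among the compounds shown, and "the series" means these compounds.

Working notes on the series. Compound 1 `Cc1cc(N[C@H](CCCCN)C(=O)NO)cc(C)c1F` is the parent, and in a physicochemical assay for lipophilicity, at pH 7.4 (a higher number here means a more lipophilic compound, a lower number a more polar compound), compound 1 gives a limit of < 3. Compound 2 `Cc1cc(N[C@H](CCCCNCc2cccc(F)c2)C(=O)NO)cc(C)c1F` also reaches only a limit, < 3, in this assay. Compound 3 `COc1ccc(CNCCCC[C@@H](Nc2cc(C)c(F)c(C)c2)C(=O)NO)cc1` likewise returns a limit of < 3 in this assay. The steps from compound 1 to compound 2 a step that the two limits leave unreadable from compound 1 to compound 2, from compound 1 to compound 3 a step that the two limits leave unreadable from compound 1 to compound 3 and from compound 2 to compound 3 a step that the two limits leave unreadable from compound 2 to compound 3 therefore give no readable size, a consequence of the limit of < 3 in this assay, at which 3 of the 3 values shown sit. Compound 4 `Cc1cc(N[C@H](CCCCNCc2ccc([N+](=O)[O-])cc2)C(=O)NO)cc(C)c1F` is the next candidate for this assay; it differs from compound 3 by nitro in place of methoxy on an aromatic carbon. Going by the values given here, no measured step covers this change, and the three limits bound nothing. Compound 4 is expected to sit at 2, between 1 and 3, with an estimated step that the limit leaves unreadable from compound 3 to compound 4 that most likely remains at the same limit.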

Compound 4, distribution coefficient: < 3
Compound 4 ended at the assay's limit; the forecaster's own chance of this, stated with the estimate: 85%; the middle value lies beyond the limit too.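

The steps to compound 4 from compound 1, compound 2 and compound 3 cannot be read, because all four compounds give the same limit: the limit of < 3 in this assay, at which 4 of the 4 values shown sit.

On these data alone, the size of each of these substituent changes in this assay remains open.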